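The source may hold more compounds than are shown below. What is called first, only, known or untested is meant among the compounds shown, and "the series" means these compounds.

Two amides sharing one core have been measured in a functional assay on the whole organism for inhibition, with Brassica rapa subsp. chinensis as the target, with a stated time of 3 days, tested at 100 ppm; on this read-out lower numbers stand for less inhibition of growth and higher numbers for more inhibition of growth at the one concentration tested. In this test, compound 1 `CCCNC(=O)/C=C/c1ccccc1` gives 15% and compound 2 `CC(C)CNC(=O)/C=C/c1ccccc1` gives 34%. Compound 2 therefore holds the higher of the two numbers. Within the data shown here, the only measured step is a number 19 percentage points higher from compound 1 to compound 2 (beyond the scatter), and it places methyl in place of hydrogen on a saturated chain carbon bound to two saturated chain carbons.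

Compound 3 `C=CCNC(=O)/C=C/c1ccccc1` has not yet been measured. It differs from compound 2 by vinyl in place of isopropyl on a saturated chain carbon bound to an amide-type nitrogen, with vinyl in place of isopropyl on a saturated chain carbon bound to an amide-type nitrogen, which also reads as isobutyl to allyl. Among the measured compounds shown here, only the one measured step bears on this change, and only in part, since no measured compound carries a double bond in this chain. The allyl chain is expected to behave more like the chain of compound 1, which gives 15%, than like isobutyl. The expected change is a number 13 percentage points lower from compound 2 to compound 3 (beyond the scatter), a modest fall. Compound 3 is estimated at 21%, with an expected range of 8% to 36%.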

Compound 3, percent growth inhibition at one concentration: 63%
Beside the measured number, compound 3's estimate is 42 percentage points below it; the measured number lies above the stated range.
By their numbers in this assay, from the lowest: compound 1; then compound 2; then compound 3.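

In this assay the saturated chain carbon bound to an amide-type nitrogen proves able to carry a double bond with a gain and not a loss: vinyl in place of isopropyl gives a number 29 percentage points higher from compound 2 to compound 3 (beyond the scatter) and so displaces the branched isobutyl chain from the top of the three. Vinyl in place of ethyl gives a number 48 percentage points higher from compound 1 to compound 3 (beyond the scatter) and is the only step here printed as large, well ahead of the methyl step that gave a number 19 percentage points higher from compound 1 to compound 2 (beyond the scatter) on the same chain. Among these compounds, the end of this chain can therefore move the read-out much further than the earlier pair showed, and branching is not the only change at this position that raises the number.

No evidence accompanies these numbers, so the reason for the rise remains unknown. From the compounds shown here alone, whether the gain belongs to the double bond itself stays open, and a propargyl chain, a longer butenyl chain or a cyclopropylmethyl group at this place would bear on that, while every comparison here still rests on the one concentration of this assay and one plant species.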